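Trifluoromethyl in Place of Nitro: Expected Cytotoxicity

The source may report more compounds than this note shows. Statements on the series, on what has been measured and on what is new or still open speak of the compounds shown alone.

Compound 1 `COc1ccc(-c2nc3cc(Cl)c(Cl)cc3[nH]2)cc1`: 18000 nM
Compound 2 `CC(=O)Nc1ccc(-c2nc3cc([N+](=O)[O-])ccc3[nH]2)cc1`: > 100000 nM

In an ADME assay on BHK cells (Mesocricetus auratus) for cytotoxicity, read by MTT assay, with a stated time of 96 h (on this read-out lower numbers stand for higher toxicity in this test and higher numbers for lower toxicity in this test), compound 1 gives 18000 nM. Compound 2 gives only a limit of the assay and not a number, > 100000 nM, so compound 2 stands at the limit of > 100000 nM in this assay, at which 1 of the 2 values shown sits. Compound 3 `CC(=O)Nc1ccc(-c2nc3cc(C(F)(F)F)ccc3[nH]2)cc1` differs from compound 2 by trifluoromethyl in place of nitro on an aromatic carbon. Among the measured compounds shown here, no step between measured compounds is known here, so the size of the change is open; a step toward somewhat higher toxicity, of modest size, is expected. Compound 3 is estimated at 60000 nM, between 20000 nM and 150000 nM. This estimate means an expected step of an at least 1.6-fold lower number from compound 2 to compound 3 (0.22 log units; that floor lies within the scatter).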

Compound 3, half-maximal cytotoxic concentration: 53000 nM
The estimate for compound 3 lay 1.1-fold (0.05 log units) above the measured number; the range from low to high includes it.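

With trifluoromethyl in place of nitro on this aromatic carbon, compound 3 gives a measured number in this assay, so this position can now be read on a scale rather than only at a limit. The change amounts to an at least 1.8-fold lower number from compound 2 to compound 3 (0.27 log units; that floor lies within the scatter). Its true size stays open because compound 2 stands only at a limit: the limit of > 100000 nM in this assay, at which 1 of the 3 values shown sits.

From the compounds shown here alone, whether an amine or a carboxylic acid on the same aromatic carbon would shift the number remains open. So does the effect of a longer chain on the amide.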